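The source may report more compounds than this note shows. Statements on the series, on what has been measured and on what is new or still open speak of the compounds shown alone.

Working notes on the series.

Compound 1 `O=C(Nc1nc2ccc(F)cc2s1)c1cn(-c2ccccc2)nc1-c1ccccc1` carries fluoro on the shared core; in a functional assay on U-87MG ATCC cells for cytotoxicity against U-87 MG (Homo sapiens), read by MTT assay, with a stated time of 72 h (on this read-out higher numbers stand for weaker inhibition and lower numbers for stronger inhibition), compound 1 gives 5570 nM, the lowest of the three numbers measured. Compound 2 `COc1ccc2nc(NC(=O)c3cn(-c4ccccc4)nc3-c3ccccc3)sc2c1` gives 40600 nM, and compound 3 `Cc1ccc2nc(NC(=O)c3cn(-c4ccccc4)nc3-c3ccccc3)sc2c1` gives 23200 nM. The two steps away from compound 1 both run the same way: a 7.3-fold higher number from compound 1 to compound 2 (0.86 log units; beyond the scatter) and a 4.2-fold higher number from compound 1 to compound 3 (0.62 log units; beyond the scatter). Between the other two, a 1.8-fold lower number from compound 2 to compound 3 (0.24 log units; within the scatter).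

Compound 4 `O=C(Nc1nc2ccc(F)cc2s1)c1cn(-c2ccccc2)nc1-c1ccc(Cl)cc1` differs from compound 1 only at the phenyl: chloro in place of hydrogen on an aromatic carbon. Among the compounds with values here, none of the measured steps touches this position; all three measured compounds keep the phenyl unchanged and vary only the group on the other ring. Within the data shown here, the measured steps therefore do not bear directly on the change to compound 4; they show only that single substituent changes have so far moved the numbers modestly. Among the measured compounds shown here, with no step at the phenyl to lean on, the expectation for compound 4 is a change no larger than those seen, most likely within the scatter, and the estimate is a 1.2-fold lower number from compound 1 to compound 4 (0.09 log units; within the scatter). Compound 4 is thus expected to give about 4500 nM, with a range from 1500 nM to 15000 nM.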

Compound 4, half-maximal inhibitory concentration: 7770 nM
Estimate against measurement, compound 4: 1.7-fold (0.24 log units) below; measured number inside the range.
By their numbers in this assay, from the lowest: compounds 1 and 4 (each within the scatter of the next); then compounds 3 and 2 (each within the scatter of the next).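

Chloro in place of hydrogen on an aromatic carbon, para to a large group, is the first change at this phenyl, and in this assay it gives a 1.4-fold higher number from compound 1 to compound 4 (0.14 log units; within the scatter) with no move beyond the scatter. Compound 4 therefore cannot be told apart from compound 1 on this read-out, so this position carries a chloro without a measurable change. The steps away from fluoro on the shared core, a 7.3-fold higher number from compound 1 to compound 2 (0.86 log units; beyond the scatter) and a 4.2-fold higher number from compound 1 to compound 3 (0.62 log units; beyond the scatter), were both beyond the scatter, whereas phenyl to 4-chlorophenyl was not. No measurement is available that would explain this result.

On these data alone, whether an amine, a carboxylic acid or a longer chain at this place would move the number beyond the scatter remains open. Also open, as far as these compounds go, is whether chloro gives the same result when methoxy or methyl replaces fluoro on the core, as in compound 2 and compound 3.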